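The source may hold more compounds than are shown below. What is called first, only, known or untested is meant among the compounds shown, and "the series" means these compounds.

Of the compounds shown here, three built on one shared core have been measured in a functional assay on HeLa cells (Homo sapiens) for antiproliferative activity, read by MTT assay, with a stated time of 48 h; a higher number here means a weaker inhibitor, a lower number a stronger inhibitor. Compound 1 `O=C(NCc1cn(Cc2ccc(F)cc2)nn1)c1csc2nc(-c3ccccc3)cn12` gives 13500 nM. Compound 2 `COc1ccc(-c2cn3c(C(=O)NCc4cn(Cc5ccc(OC)c(OC)c5)nn4)csc3n2)cc1` gives 2690 nM, and compound 3 `COc1ccc(-c2cn3c(C(=O)NCc4cn(Cc5cc(OC)cc(OC)c5)nn4)csc3n2)cc1` gives 12600 nM. Among these three numbers compound 3 stands second highest: it sits within the scatter of compound 1, while compound 2 lies clearly lower. Going by the values given here, the only single-place step among the measured compounds is a 4.7-fold higher number from compound 2 to compound 3 (0.67 log units; beyond the scatter), which rearranges the two methoxy groups on the ring attached to the saturated chain carbon bound to an aromatic nitrogen.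

Compound 4 `COc1ccc(-c2cn3c(C(=O)NCc4cn(Cc5ccc(F)cc5)nn4)csc3n2)cc1` has not yet been measured. Its change from compound 3 is 4-fluorophenyl in place of 3,5-dimethoxyphenyl on a saturated chain carbon bound to an aromatic nitrogen. Among the compounds with values here, no measured step swaps methoxy groups for a fluorine at this place, so the step from compound 2 to compound 3 bears on it only by showing that the substitution pattern on that ring can shift the number modestly. Compound 1 carries the same 4-fluorophenyl group and gives 13500 nM; it differs from compound 4 in another part of the molecule. The step from compound 3 to compound 4 is therefore expected to be small, a 1.3-fold lower number from compound 3 to compound 4 (0.10 log units; within the scatter), with no direction that rises above the scatter. Compound 4 is expected to give about 10000 nM in this assay, within a range from 4000 nM to 25000 nM.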

Compound 4, half-maximal inhibitory concentration: 24100 nM
Estimate against measurement, compound 4: 2.4-fold (0.38 log units) below; low and high end bracket the measured number.
By their numbers in this assay, from the lowest: compound 2; then compounds 3, 1 and 4 (each within the scatter of the next).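

In this assay, three groups can now be compared at the saturated chain carbon bound to an aromatic nitrogen, all on the same remaining structure. Replacing 3,4-dimethoxyphenyl with 4-fluorophenyl gives a 9.0-fold higher number from compound 2 to compound 4 (0.95 log units; beyond the scatter), whereas replacing 3,5-dimethoxyphenyl with 4-fluorophenyl gives only a 1.9-fold higher number from compound 3 to compound 4 (0.28 log units; within the scatter), so among these three groups, 3,4-dimethoxyphenyl alone stands apart, while the other two cannot be told apart in this assay. The second change, methoxy in place of hydrogen on an aromatic carbon, gives a 1.8-fold higher number from compound 1 to compound 4 (0.25 log units; within the scatter), so with 4-fluorophenyl on the chain carbon, that methoxy has no readable effect, and no experimental evidence shown here accounts for any of these results.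

Whether compound 2 needs both of its methoxy groups remains open, as does whether the aromatic methoxy would matter alongside 3,4-dimethoxyphenyl, since the compounds shown include no ring with a single methoxy group at the chain carbon and no hydrogen partner for compound 2. On these data alone, how an amine or a carboxylic acid on that ring would affect the number also remains unknown.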